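The compounds below may be only part of what the source reports. "The series", "measured", "known", "first", "only" and "open" are said of these compounds alone.

Measured compounds:
Compound 1, `Cc1ccc(NC(=O)N[C@H]2CC[C@H](Oc3ccc(F)cc3)CC2)cc1`, > 20000 nM in a functional assay on CRL2813 cells (Homo sapiens) for cytotoxicity, read by sulforhodamine B assay, with a stated time of 5 days; on this read-out lower numbers stand for stronger inhibition and higher numbers for weaker inhibition
Compound 2, `O=C(Nc1cccc(Cl)c1)N[C@H]1CC[C@H](Oc2ccc(F)cc2)CC1`, 5900 nM

Compound 1 gives only a limit in this assay, > 20000 nM, so no number stands for it. Compound 2 holds the only number shown, 5900 nM. Within the data shown here, the one step that joins the two is an at least 3.3-fold lower number from compound 1 to compound 2 (0.53 log units; beyond the scatter). Because compound 1 sits at the limit described in the limit of > 20000 nM in this assay, at which 1 of the 2 values shown sits, the true size of that step is not known beyond its lower bound.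

Compound 3, `COc1ccc(NC(=O)N[C@H]2CC[C@H](Oc3ccc(F)cc3)CC2)cc1`, is not yet measured in this assay. It differs from compound 2 in one place: 4-methoxyphenyl in place of 3-chlorophenyl on an amide-type nitrogen. Among the measured compounds shown here, the only measured step, from compound 1 to compound 2, shows that exchanging a 4-methylphenyl for a 3-chlorophenyl brought the number down by at least a modest amount. Compound 3 returns to a 4-substituted phenyl, now 4-methoxyphenyl, and so resembles compound 1 rather than compound 2 in the group that is changed; the step back toward compound 1 is expected to raise the number, with a real chance that only a limit is reported. The step from compound 2 to compound 3 is therefore estimated as a 2.5-fold higher number from compound 2 to compound 3 (0.41 log units; beyond the scatter). For compound 3 the expected value in this assay is 15000 nM, within a range of 5000 nM to 40000 nM.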

Compound 3, half-maximal inhibitory concentration: > 20000 nM
Compound 3: only a limit was reported; the forecaster's own chance of this, stated with the estimate: 45%; middle value at least 1.3-fold (0.12 log units) from the limit.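

Compound 3 gives only a limit in this assay, > 20000 nM. Putting 4-methoxyphenyl in place of 3-chlorophenyl on the amide-type nitrogen gives an at least 3.3-fold higher number from compound 2 to compound 3 (0.53 log units; beyond the scatter), so 3-chlorophenyl now stands apart from two different groups at this place, 4-methylphenyl and 4-methoxyphenyl, and compound 2 alone of the three carries a number. Compound 1 and compound 3 cannot be ranked against each other, and the step between them cannot be read, because both values are limits: the limit of > 20000 nM in this assay, at which 2 of the 3 values shown sit.

What the compounds shown leave open is whether the number in compound 2 follows from the chlorine itself or from where the substituent stands on the phenyl ring, since the group name changes in both respects at once from compound 2 to either of the others. From the compounds shown here alone, a 4-chlorophenyl, a 3-methylphenyl or a 3-methoxyphenyl on the same nitrogen would separate those two readings, and how far the number falls below that of compound 2 with any other group at this place also remains unknown.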